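A few compounds are considered here, and "the series" means these few. Any claim that something is new, unique, unknown or untested is made for them only; others in the source may bear on it.

Three measured compounds share one core and differ only in the group attached to the carbonyl carbon of the amide. Compound 1 `CCOC(=O)N1CCC(N2CCC[C@@H](NC(=O)C3CCCCC3)C2)CC1` carries a cyclohexyl there. In a functional assay on CHO cells for agonist activity at muscarinic acetylcholine receptor M5 (Rattus norvegicus) (on this read-out lower numbers stand for an effect already at smaller amounts and higher numbers for an effect only at larger amounts of compound), compound 1 gives > 10000 nM, which is a limit of the assay and not a number. Compound 2 `CCOC(=O)N1CCC(N2CCC[C@@H](NC(=O)c3ccc(C)cc3)C2)CC1` carries a 4-methylphenyl in that place. In this assay compound 2 gives > 10000 nM, again a limit. Compound 3 `CCOC(=O)N1CCC(N2CCC[C@@H](NC(=O)C3CCCC3)C2)CC1` carries a cyclopentyl. In this assay compound 3 gives > 10000 nM, also a limit. Compound 3 thus stands where the other two stand, at the limit of > 10000 nM in this assay, at which 3 of the 3 values shown sit, and none of the steps between them can be sized: a step that the two limits leave unreadable from compound 1 to compound 2, a step that the two limits leave unreadable from compound 1 to compound 3 and a step that the two limits leave unreadable from compound 2 to compound 3.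

Compound 4 `CCOC(=O)N1CCC(N2CCC[C@@H](NC(=O)c3cccs3)C2)CC1` continues this series: thiophen-2-yl in place of cyclopentyl on a carbonyl carbon. The measured steps bear on this change only in one way: every exchange of the group on the carbonyl carbon so far left the value at the limit of > 10000 nM in this assay, at which 3 of the 3 values shown sit, so neither a direction nor a size can be read from them. The expectation for compound 4 in this assay is therefore that it stays at the limit, estimated as 15000 nM with a range from 4000 nM to 60000 nM. Expressed as a step, the expected change is a step that the limit leaves unreadable from compound 3 to compound 4.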

Compound 4, half-maximal effective concentration: > 10000 nM
Compound 4 gave a limit, no number; the forecaster's own chance of this, stated with the estimate: 85%; the middle value lies beyond the limit too.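

Compound 4 also stops at a limit in this assay, as do compound 1, compound 2 and compound 3, so no step from any of them to compound 4 can be read: the limit of > 10000 nM in this assay, at which 4 of the 4 values shown sit.

The compounds shown leave open whether exchanging the group on the carbonyl carbon changes the value at all, and in which direction.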